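From Nitrophenyl to Cyanophenyl on a Shared Core

A few compounds are considered here, and "the series" means these few. Any claim that something is new, unique, unknown or untested is made for them only; others in the source may bear on it.

In an ADME assay on L02 cells (Homo sapiens) for cytotoxicity, read by MTT assay, with a stated time of 24 h (on this read-out lower numbers stand for stronger inhibition and higher numbers for weaker inhibition), compound 1 (`COc1cc(/C=C2\CN(C)C/C(=C\c3ccc(Cl)cc3)C2=O)cc(OC)c1`) gives 18900 nM while compound 2 (`COc1cc(/C=C2\CN(C)C/C(=C\c3ccc(Br)cc3)C2=O)cc(OC)c1`) gives 21300 nM and compound 3 (`COc1cc(/C=C2\CN(C)C/C(=C\c3cccc([N+](=O)[O-])c3)C2=O)cc(OC)c1`) gives 10800 nM so all three sit within the usual scatter of one another. Compound 4 (`COc1cc(/C=C2\CN(C)C/C(=C\c3ccc(C#N)cc3)C2=O)cc(OC)c1`) differs from compound 3 in one place (4-cyanophenyl in place of 3-nitrophenyl on a double-bonded chain carbon bound to a double-bonded ring carbon). Exchanging this aromatic group has so far moved the number little (a 1.8-fold lower number from compound 1 to compound 3 (0.24 log units; within the scatter) and a 2.0-fold lower number from compound 2 to compound 3 (0.29 log units; within the scatter)), and swapping one halogen for another did the same (a 1.1-fold higher number from compound 1 to compound 2 (0.05 log units; within the scatter)). Each of these steps stays within the scatter. No step beyond the scatter is therefore expected in this assay and the estimated step is small (a 1.3-fold higher number from compound 3 to compound 4 (0.11 log units; within the scatter)). Compound 4 is expected at 14000 nM with 7500 nM to 26000 nM as its estimated range.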

Compound 4, half-maximal inhibitory concentration: 14000 nM
Beside the measured number, compound 4's estimate shows no gap at the digits printed, and the stated range covers the measured number.
By their numbers in this assay, from the lowest: compounds 3, 4, 1 and 2 (each within the scatter of the next).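

In this assay, the 4-cyanophenyl group at this place also stays within the scatter of the three earlier aromatic groups (a 1.3-fold higher number from compound 3 to compound 4 (0.11 log units; within the scatter); a 1.5-fold lower number from compound 2 to compound 4 (0.18 log units; within the scatter); a 1.4-fold lower number from compound 1 to compound 4 (0.13 log units; within the scatter)). A nitrile on the aromatic carbon therefore reads much like chloro or bromo there, and all four compounds remain alike in this measurement. Nothing measured here explains this likeness. Going by these compounds, it remains open whether an amine or a carboxylic acid in place of the cyano on an aromatic carbon would shift the number beyond the scatter.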